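The source may report more compounds than this note shows. Statements on the series, on what has been measured and on what is new or still open speak of the compounds shown alone.

Measured so far in an in vitro ADME assay on microsomes from liver (Homo sapiens) for metabolic stability; on this read-out lower numbers stand for slow clearance and higher numbers for fast clearance:
- compound 1 (`COCc1ccccc1C1CCc2nc[nH]c2C1`): < 7 mL.min-1.g-1; < 7 mL.min-1.g-1 (2 entries) (a limit of the assay in both entries, not a number)
- compound 2 (`COc1ccc(C2CCc3nc[nH]c3C2)cc1`): 16 mL.min-1.g-1 (a single measurement)
- compound 3 (`COc1cccc(C2CCc3nc[nH]c3C2)c1`): "not determined" (no result reported)

Compound 3 therefore has no number on this read-out, and the step from it has no measured starting point. Compound 4 (`c1ccc(C2CCc3nc[nH]c3C2)cc1`) is the next structure to be measured. The change hydrogen in place of methoxy on an aromatic carbon puts hydrogen in place of methoxy on an aromatic carbon. Among the compounds with values here, no pair of measured compounds differs in one place, so no measured step can guide the size of this one. No step beyond the usual scatter is expected, and no direction can be given while compound 3 lacks a value. The nearest guide is compound 2 at 16 mL.min-1.g-1 as a single number from the series. Compound 1 sits at < 7 mL.min-1.g-1; < 7 mL.min-1.g-1 (2 entries) as a limit of the assay. Compound 4 is expected at 9 mL.min-1.g-1 in an estimated range of 4 mL.min-1.g-1 to 22 mL.min-1.g-1 on this read-out.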

Compound 4, intrinsic clearance in microsomes: 7 mL.min-1.g-1
The estimate for compound 4 lay 1.3-fold (0.11 log units) above the measured number, and the stated range covers the measured number.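

Hydrogen in place of methoxy on an aromatic carbon has a size on one comparison in this assay, which gives a 2.3-fold lower number from compound 2 to compound 4 (0.36 log units; beyond the scatter), the only readable one-place step in the series and one that lies beyond the usual scatter. The step from compound 3 cannot be read, so the change meta to a group of 9 heavy atoms remains without a size. No measurement at hand accounts for the step from the methoxy compound.

Open, as far as these compounds go, is whether the methoxy group of compound 3 would give a step of similar size and direction to that of compound 2. Also open, from the compounds shown here alone, is how other groups on the same aromatic ring, such as fluorine, an amine or a carboxylic acid, would read out against hydrogen in compound 4.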